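Chloro for Methyl: Expected Cytotoxicity of Compound 4

The source may hold more compounds than are shown below. What is called first, only, known or untested is meant among the compounds shown, and "the series" means these compounds.

Compound 2 `Cc1cccc(-n2cc(-c3ccccc3NS(=O)(=O)c3c[nH]c(=O)[nH]c3=O)nn2)c1` gives 21900 nM in an ADME assay on L02 cells (Homo sapiens) for cytotoxicity, read by MTT assay, with a stated time of 24 h; on this read-out lower numbers stand for higher toxicity in this test and higher numbers for lower toxicity in this test. Of the two plain numbers shown, this is the lowest: compound 1 `Cc1ccccc1-n1cc(-c2ccccc2NS(=O)(=O)c2c[nH]c(=O)[nH]c2=O)nn1` gives 56600 nM in this assay, and the step of a 2.6-fold lower number from compound 1 to compound 2 (0.41 log units; beyond the scatter) lies beyond the scatter. Compound 3 `O=c1[nH]cc(S(=O)(=O)Nc2ccccc2-c2cn(-c3ccccc3F)nn2)c(=O)[nH]1` reaches only a limit of this assay, > 100000 nM, so for it no number is known.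

Compound 4 `O=c1[nH]cc(S(=O)(=O)Nc2ccccc2-c2cn(-c3cccc(Cl)c3)nn2)c(=O)[nH]1` differs from compound 2 by chloro in place of methyl on an aromatic carbon. Among the compounds with values here, two measured steps bear on this. The step of an at least 1.7-fold higher number from compound 1 to compound 3 (0.24 log units; that floor lies within the scatter) shows that exchanging methyl for a halogen, at a different spot on the same ring, did not move the number beyond the scatter. The step of an at least 4.5-fold higher number from compound 2 to compound 3 (0.65 log units; beyond the scatter) combines that exchange with a shift of position and ends at the limit (the limit of > 100000 nM in this assay, at which 1 of the 3 values shown sits), so it is less direct a guide. A small rise, or none beyond the scatter, is therefore expected. Compound 4 is estimated at 32000 nM, within 12000 nM to 85000 nM, which would mean a step of a 1.5-fold higher number from compound 2 to compound 4 (0.16 log units; within the scatter).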

Compound 4, half-maximal cytotoxic concentration: > 100000 nM
Compound 4 gave a limit, no number (the forecaster's own chance of this, stated with the estimate: 12%); at least 3.1-fold (0.49 log units) between middle value and limit.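

The change from 3-methylphenyl to 3-chlorophenyl gives, in this assay, an at least 4.5-fold higher number from compound 2 to compound 4 (0.65 log units; beyond the scatter), which means lower toxicity in this test. Within the data shown here, this is the first step that changes only the group at this one place on the ring, whereas the earlier step to compound 3 also moved the place of the substituent. The step to the 2-methylphenyl compound reads an at least 1.7-fold higher number from compound 1 to compound 4 (0.24 log units; that floor lies within the scatter), so that floor alone does not separate the two compounds, and the step between compound 3 and compound 4 cannot be read, as both values are limits.

From the compounds shown here alone, how far compound 4 actually lies past its limit stays unknown: the limit of > 100000 nM in this assay, at which 2 of the 4 values shown sit. Whether an amine or a carboxylic acid at this place would give a measurable number also remains open.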